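This account rests on a few compounds, and the source may have more. Where it says the series, first, only, none or still open, it means among the compounds named here.

Compound 1 `CS(=O)(=O)c1ccc(Nc2ncc(F)c(Nc3nc4ccccc4s3)n2)cc1`: 3170 nM; compound 2 `Cc1cnc(Nc2ccc(S(C)(=O)=O)cc2)nc1Nc1nc2ccccc2s1`: 460 nM; compound 3 `NS(=O)(=O)c1ccc(Nc2nccc(Nc3nc4ccc(F)cc4s3)n2)cc1`: 450 nM.

In a functional assay on HeLa cells (Homo sapiens) for antiproliferative activity, read by MTT assay, with a stated time of 48 h (a higher number here means a weaker inhibitor, a lower number a stronger inhibitor), compound 1 gives 3170 nM, compound 2 gives 460 nM and compound 3 gives 450 nM. The change from compound 1 to compound 2 is methyl in place of fluoro on an aromatic carbon, and it made a 6.9-fold lower number from compound 1 to compound 2 (0.84 log units; beyond the scatter). Compound 3 and compound 4 `Cc1ccc2nc(Nc3ccnc(Nc4ccc(S(N)(=O)=O)cc4)n3)sc2c1` differ by methyl in place of fluoro on an aromatic carbon, the same kind of change, though here the place is a six-membered aromatic ring of carbon only within a fused system, meta and para to a fused ring, rather than a ring with 2 nitrogen near large groups. How the core of compound 3 differs from that of compound 1 is not broken down here. Compound 4 is expected to show a smaller step, a 1.5-fold lower number from compound 3 to compound 4 (0.18 log units; within the scatter), because compound 3 already stands at 450 nM and the earlier step sat on a different ring. The estimate for compound 4 is 300 nM, between 100 nM and 1000 nM.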

Compound 4, half-maximal inhibitory concentration: 660 nM
Beside the measured number, compound 4's estimate is 2.2-fold (0.34 log units) below it; the range from low to high includes it.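

In this assay, methyl in place of fluoro on the six-membered aromatic ring of carbon only, part of a fused system, gave a 1.5-fold higher number from compound 3 to compound 4 (0.17 log units; within the scatter). The change therefore did not carry over with the same size from one core to the other: the same change on two cores in this assay, a 6.9-fold lower number (0.84 log units; beyond the scatter) from compound 1 to compound 2 and a 1.5-fold higher number (0.17 log units; within the scatter) from compound 3 to compound 4, 10-fold (1.00 log units) apart, beyond the scatter of two such steps. This does not show what lies behind the gap, since the two steps differ in both core and place, and two pairs support no general rule for the series.

The compounds shown leave open what methyl in place of fluoro would do on the ring with 2 nitrogen of the core of compound 3. They also leave open how a chloro, methoxy or amine group would fare at either place.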